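Replacing the acid-bearing aryl in the series

The source may hold more compounds than are shown below. What is called first, only, known or untested is meant among the compounds shown, and "the series" means these compounds.

Values below come from an assay on HEK293 cells for positive allosteric modulation of metabotropic glutamate receptor 2 (Rattus norvegicus), read by thallium flux; a lower number here means that less compound is needed, a higher number that more compound is needed for the effect.

Compound 1 `O=C(O)c1cc(-c2cccc(COc3ccc4c(c3)CN(C3CCCC3)C4=O)c2)ccc1O`: 20 nM
Compound 2 `O=C(O)c1ccc(-c2cccc(COc3ccc4c(c3)CN(C3CCCC3)C4=O)c2)c(Cl)c1`: 110 nM
Compound 3 `COc1ccc(C(=O)O)cc1-c1cccc(COc2ccc3c(c2)CN(C2CCCC2)C3=O)c1`: 80 nM

Compound 1 has the lowest number of the three. The two measured changes both alter the same aryl group on the shared core: a 5.5-fold higher number from compound 1 to compound 2 (0.74 log units; beyond the scatter) and a 4.0-fold higher number from compound 1 to compound 3 (0.60 log units; beyond the scatter), each a modest rise beyond the scatter, while compounds 2 and 3 sit within the scatter of each other (a 1.4-fold lower number from compound 2 to compound 3 (0.14 log units; within the scatter)). In both measured steps a carboxylic acid is kept, only moved or paired with another substituent.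

Compound 4 `O=C1c2ccc(OCc3cccc(-c4ccc(Cl)cc4F)c3)cc2CN1C1CCCC1` goes further: 4-chloro-2-fluorophenyl in place of 3-carboxy-4-hydroxyphenyl on an aromatic carbon. The entering group carries no hydrogen-bond donor or acceptor, whereas the leaving group carries both. Within the data shown here, no measured step removes the acid, so only the direction of the two measured steps can guide the expectation: both raise the number when the group is altered, and a change that drops the acid altogether is expected to raise it at least as much, probably more. For compound 4 the expected step is a 15-fold higher number from compound 1 to compound 4 (1.18 log units; beyond the scatter). Compound 4 is therefore estimated at 300 nM, with a range from 60 nM to 2000 nM, the wide range reflecting that nothing measured here covers loss of the acid.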

Compound 4, half-maximal effective concentration: > 5000 nM
Compound 4 ended at the assay's limit; the forecaster's own chance of this, stated with the estimate: 10%; at least 16-fold (1.22 log units) between middle value and limit.
By their numbers in this assay, from the lowest: compound 1; then compounds 3 and 2 (each within the scatter of the next). At a limit, above all of these: compound 4.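

In this assay, compound 4 stands at a limit of the assay and not at a number: the limit of > 5000 nM in this assay, at which 1 of the 4 values shown sits. The earlier changes all kept a carboxylic acid on this aryl group and moved the number only modestly, whereas 4-chloro-2-fluorophenyl gives an at least 250-fold higher number from compound 1 to compound 4 (2.39 log units; beyond the scatter), with an at least 62-fold higher number from compound 3 to compound 4 (1.79 log units; beyond the scatter) and an at least 45-fold higher number from compound 2 to compound 4 (1.65 log units; beyond the scatter) as the matching steps from the other two acids. Among these compounds, at this position, then, the largest separation in the set falls between the three carboxylic acid compounds and the one compound without that group, whose entering group has no hydrogen-bond donors or acceptors, and each of the three steps is large rather than modest.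

Compound 4 loses the carboxylic acid and the hydroxyl or other partner substituent and gains chlorine and fluorine in a single change, so the share of the acid alone stays unresolved, and the limit leaves the true size of each step unfixed. Going by these compounds, whether a tetrazole, a primary amide or a hydroxymethyl group in the place of the carboxylic acid would keep the number close to those of compound 1, compound 2 and compound 3 remains open.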